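The compounds below may be only part of what the source reports. "The series", "measured", "known", "first", "only" and "open" are said of these compounds alone.

Compound 1 `S=C(c1ccccc1)N1CCOCC1` gives > 1000000 nM in an assay on isolated protein for inhibition of Fatty-acid amide hydrolase 1 (Homo sapiens), read by scintillation counting, with a stated time of 10 min (a lower number here means a stronger inhibitor, a higher number a weaker inhibitor), a limit of the assay and not a number.
Compound 2 `S=C(c1ccccc1Cl)N1CCOCC1` gives > 1000000 nM in this assay, again a limit rather than a number.

Compound 1 therefore stands only at a limit in this assay, sharing the limit of > 1000000 nM in this assay, at which 2 of the 2 values shown sit, with the other measured compound. Among the compounds with values here, the single measured step, a step that the two limits leave unreadable from compound 1 to compound 2, introduces chloro in place of hydrogen on an aromatic carbon, and because both of its ends sit at the limit of > 1000000 nM in this assay, at which 2 of the 2 values shown sit, its size cannot be read. Compound 3 `O=[N+]([O-])c1cccc(C(=S)N2CCOCC2)c1` differs from compound 1 by nitro in place of hydrogen on an aromatic carbon, a nitro in place of hydrogen on an aromatic carbon. Within the data shown here, no measured step bears readably on this change, so the measured data give no direction and no size to expect beyond the scatter, only that the shared core and its phenyl substitution have so far produced nothing measurable in this assay. Compound 3 is therefore expected to remain at or near the limit, with an estimated step of a number no higher from compound 1 to compound 3 (the limit leaves the size open). The estimate for compound 3 in this assay is 1000000 nM, with a range from 200000 nM to 5000000 nM.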

Compound 3, half-maximal inhibitory concentration: 245000 nM
For compound 3 the middle estimate is 4.1-fold (0.61 log units) above the measured one; low and high end bracket the measured number.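

In this assay, within the data shown here, nitro on an aromatic carbon, meta to a group of 8 heavy atoms, gives the first reading that is a number and not a limit, with an at least 4.0-fold lower number from compound 1 to compound 3 (0.61 log units; beyond the scatter). This step is only a bound, and the real distance may be larger, as the starting end of the step is a limit and not a number. It shows that one change on the six-membered aromatic ring can bring the shared core into the measurable range of this assay, something the earlier pair could not show, as the step between those two compounds cannot be read and both remain at the limit: the limit of > 1000000 nM in this assay, at which 2 of the 3 values shown sit.

Going by these compounds, compound 3 alone cannot separate the effect of the nitro group from that of its place on the ring, so it remains open whether the same group elsewhere on the ring would give a similar number. On these data alone, it also remains open whether an amine, a nitrile or a carboxylic acid in the same place would lower the number as far, or further.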